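This account rests on a few compounds, and the source may have more. Where it says the series, first, only, none or still open, it means among the compounds named here.

Measured so far in a functional assay on MDA-MB-231 cells (Homo sapiens) for inhibition, read by MTT assay, with a stated time of 24 h; a lower number here means a stronger inhibitor, a higher number a weaker inhibitor:
- compound 1, `CCc1cc2ccccc2nc1-c1cc(-c2ccc(F)cc2)no1`: > 100000 nM
- compound 2, `CCCc1cc2ccccc2nc1-c1cc(-c2ccc(F)cc2)no1`: 48400 nM
- compound 3, `CCCCc1cc2ccccc2nc1-c1cc(-c2ccc(F)cc2)no1`: 24200 nM

The value of compound 1 is a limit of this assay, not a number (the limit of > 100000 nM in this assay, at which 1 of the 3 values shown sits). Compound 3 gives the lowest number of the two that are numbers, but a 2.0-fold lower number from compound 2 to compound 3 (0.30 log units; within the scatter) is within the scatter, so compound 3 and compound 2 cannot be told apart. The steps that are beyond the scatter run from the limit: an at least 2.0-fold lower number from compound 1 to compound 2 (0.31 log units; beyond the scatter) and an at least 4.1-fold lower number from compound 1 to compound 3 (0.61 log units; beyond the scatter). All three measured steps concern the length of the saturated chain on the shared core; none touches the aryl ring on the other side.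

Compound 4, `CCCCc1cc2ccccc2nc1-c1cc(-c2ccc(C)cc2)no1`, differs from compound 3 in that ring only: methyl in place of fluoro on an aromatic carbon. Going by the values given here, no measured step bears on this change, so the expectation rests on compound 3 alone and on the small size of the exchange. The step of a 1.0-fold lower number from compound 3 to compound 4 (0.00 log units; within the scatter) is expected to stay within the scatter, in no set direction. Compound 4 is therefore estimated at 24000 nM in this assay, with a range from 8000 nM to 80000 nM.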

Compound 4, half-maximal inhibitory concentration: > 100000 nM
Compound 4: only a limit was reported; the forecaster's own chance of this, stated with the estimate: 10%; middle value at least 4.1-fold (0.61 log units) from the limit.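

Going by these compounds alone, the aryl ring of the shared core, untouched by the earlier compounds, turns out not to be a silent position: in this assay, the change from 4-fluorophenyl to 4-methylphenyl gives an at least 4.1-fold higher number from compound 3 to compound 4 (0.61 log units; beyond the scatter). With the chain of compound 3 kept, compound 4 gives > 100000 nM, which is a limit of this assay and not a number, so a longer saturated chain alone does not secure a measurable value, and an exchange of one heavy atom, methyl in place of fluoro para to a large group, is enough to lose it. The size of this step has only a lower bound, and the series now has a second compound at the ceiling: the limit of > 100000 nM in this assay, at which 2 of the 4 values shown sit.

Open, as far as these compounds go, is whether the fluoro group or the methyl group decides this step; a plain hydrogen, a chloro group or a methoxy group at this place would separate the two. Also open, from the compounds shown here alone, is whether a longer chain, or an amine or a carboxylic acid on this ring, would lower the number further or leave it at the limit.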